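The compounds below may be only part of what the source reports. "The series", "measured", "known", "first", "only" and "open" are said of these compounds alone.

In a functional assay on MDA-MB-231 cells (Homo sapiens) for cytotoxicity, read by MTT assay, with a stated time of 72 h (a higher number here means a weaker inhibitor, a lower number a stronger inhibitor), compound 1 `CCCCCCNc1nc(SCc2ccc(C(F)(F)F)cc2)nc2ccccc12` gives 20200 nM. Compound 2 `COc1ccccc1Nc1nc(SCc2ccc(C(F)(F)F)cc2)nc2ccccc12` reaches only the limit of the assay, > 50000 nM. Compound 3 `CCOc1ccccc1Nc1nc(SCc2ccc(C(F)(F)F)cc2)nc2ccccc12` likewise stops at the assay limit, > 50000 nM, so its standing is known only as a floor, one it shares with another compound (the limit of > 50000 nM in this assay, at which 2 of the 3 values shown sit). The step of an at least 2.4-fold higher number from compound 1 to compound 2 (0.39 log units; beyond the scatter) and the step of an at least 2.4-fold higher number from compound 1 to compound 3 (0.39 log units; beyond the scatter) both run toward weaker inhibition when the hexyl chain on a nitrogen on an aromatic ring is replaced by an aryl group carrying an alkoxy substituent. The step that the two limits leave unreadable from compound 2 to compound 3 lies between two limits and cannot be read. Compound 4 `Fc1ccc(Nc2nc(SCc3ccc(C(F)(F)F)cc3)nc3ccccc23)cc1` keeps the shared core and differs from compound 3 in one place: 4-fluorophenyl in place of 2-ethoxyphenyl on a nitrogen on an aromatic ring. Compound 4 is therefore a third aryl amine at that nitrogen, and the two measured aryl amines, compound 2 and compound 3, both sit at the limit. For compound 4 the outcome in this assay is estimated at 60000 nM, with a range from 20000 nM to 150000 nM. The expected step that the limit leaves unreadable from compound 3 to compound 4 would most likely remain unreadable, with compound 4 again at the limit.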

Compound 4, half-maximal inhibitory concentration: 15000 nM
Beside the measured number, compound 4's estimate is 4.0-fold (0.60 log units) above it; the measured number lies below the stated range.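

In this assay, the change to 4-fluorophenyl gives an at least 3.3-fold lower number from compound 3 to compound 4 (0.52 log units; beyond the scatter) and an at least 3.3-fold lower number from compound 2 to compound 4 (0.52 log units; beyond the scatter), so a phenyl ring on this nitrogen does not by itself bring the number up to the limit. Set against the hexyl chain, the same group gives a 1.3-fold lower number from compound 1 to compound 4 (0.13 log units; within the scatter), which leaves compound 1 and compound 4 indistinguishable in this assay. Among the aryl amines shown, only compound 2 and compound 3, with their alkoxy-bearing rings, remain at a limit rather than a number: the limit of > 50000 nM in this assay, at which 2 of the 4 values shown sit.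

The step between compound 2 and compound 3 cannot be read, and the move from 2-ethoxyphenyl to 4-fluorophenyl changes both the substituent and where it sits, so the two contributions cannot be separated. Going by these compounds, how an unsubstituted phenyl, 2-fluorophenyl or 4-methoxyphenyl would behave at this nitrogen remains open.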